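Another nitrophenyl sulfonyl group at the assay limit

The compounds below may be only part of what the source reports. "The series", "measured", "known", "first", "only" and "open" are said of these compounds alone.

Values in an ADME assay on HEK293 cells (Homo sapiens) for antiproliferative activity, read by MTT assay, with a stated time of 48 h (on this read-out higher numbers stand for weaker inhibition and lower numbers for stronger inhibition), each one a limit of the assay:
compound 1 `Cc1ccc(S(=O)(=O)n2cc(/C=C/C(=O)c3ccncc3)c3ccccc32)cc1`: > 150000 nM
compound 2 `O=C(/C=C/c1cn(S(=O)(=O)c2cccc([N+](=O)[O-])c2)c2ccccc12)c1ccncc1`: > 150000 nM
compound 3 `O=C(/C=C/c1cn(S(=O)(=O)c2cccc3ccccc23)c2ccccc12)c1ccncc1`: > 150000 nM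

Compound 3 has no number, only its limit of > 150000 nM. The whole set gives (the limit of > 150000 nM in this assay, at which 3 of the 3 values shown sit). Compound 4 `O=C(/C=C/c1cn(S(=O)(=O)c2ccccc2[N+](=O)[O-])c2ccccc12)c1ccncc1` carries 2-nitrophenyl in place of naphthalen-1-yl on a sulfonyl sulfur.

Three measured steps change this same group: a step that the two limits leave unreadable from compound 1 to compound 2, a step that the two limits leave unreadable from compound 1 to compound 3 and a step that the two limits leave unreadable from compound 2 to compound 3. None has a readable size, so they offer no direction. The last is closest to the new change, as it also exchanges a nitrophenyl group and naphthalen-1-yl.

Compound 2, with 3-nitrophenyl, also has only a limit, > 150000 nM, and on that ground compound 4 is expected to report a limit too. In this assay the expected change is a step that the limit leaves unreadable from compound 3 to compound 4, with no direction claimed. For compound 4 the estimated value is 170000 nM, with an expected range of 100000 nM to 300000 nM.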

Compound 4, half-maximal inhibitory concentration: > 150000 nM
Compound 4: no number, only a limit; the forecaster's own chance of this, stated with the estimate: 88%; the middle value lies beyond the limit too.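

In this assay compound 4 gives > 150000 nM, which is a limit and not a number, so its steps from compound 1, compound 2 and compound 3 cannot be read. The compounds shown leave open whether changing the group on the sulfonyl sulfur alters the value at all: the limit of > 150000 nM in this assay, at which 4 of the 4 values shown sit.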